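The compounds below may be only part of what the source reports. "The series", "measured", "known", "first", "only" and "open" are said of these compounds alone.

Of the compounds shown here, three built on one shared core have been tested in a functional assay on BJAB cells (Homo sapiens) for antiproliferative activity, with a stated time of 4 days; a lower number here means that less compound is needed, a higher number that more compound is needed for the effect. Compound 1 `Cc1c(-c2cc(Cl)cc(Cl)c2)c(C(=O)O)nn1-c1nc(-c2ccncc2)c(SC(C)C)s1` is reported in this assay as "not active" (no number reported), with no number attached. Compound 2 `Cc1nn(-c2nc(-c3ccc(Cl)c(Cl)c3)c(SC(C)C)s2)c(C(=O)O)c1-c1cccc(Cl)c1C` gives 5100 nM in this assay. Compound 3 `Cc1nn(-c2nc(-c3ccc(Cl)c(Cl)c3)c(SC(C)C)s2)c(C(=O)O)c1-c1cc(C(F)(F)F)cc(C(F)(F)F)c1` gives 1800 nM in this assay. Of the two compounds with a number, compound 2 stands highest: compound 3 gives the lower number, and the gap between them lies beyond the usual scatter of repeated measurements, so more of compound 2 is needed for the same effect.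

Compound 4 `Cc1nn(-c2nc(-c3ccc(Cl)c(Cl)c3)c(SC(C)C)s2)c(C(=O)O)c1Cc1ccccc1[N+](=O)[O-]` has not yet been measured. It differs from compound 2 in one place: 2-nitrobenzyl in place of 3-chloro-2-methylphenyl on an aromatic carbon. The change sits on an aromatic carbon of a five-membered aromatic ring with two nitrogen, next to the ring atom that bears a carboxy group and next to the ring atom that bears a methyl group.

Among the measured compounds shown here, no measured pair shows a change of this kind, so there is no measured step to lean on. The expectation for compound 4 is a modest shift in this assay, more likely toward a higher number than compound 2, with a real chance that no number is reported at all. Compound 4 is expected to give 7000 nM in this assay, within a range from 1500 nM to 30000 nM. This estimate means an expected step of a 1.4-fold higher number from compound 2 to compound 4 (0.14 log units; within the scatter), which may yet fall within the scatter.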

Compound 4, half-maximal effective concentration: 20000 nM
Estimate against measurement, compound 4: 2.9-fold (0.46 log units) below, within the range that was stated.
By their numbers in this assay, from the lowest: compound 3; then compound 2; then compound 4.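

In this assay, among the compounds shown here, this is the first measured step at this aromatic carbon of the five-membered ring with 2 nitrogen, and replacing 3-chloro-2-methylphenyl with 2-nitrobenzyl gives a 3.9-fold higher number from compound 2 to compound 4 (0.59 log units; beyond the scatter), so the number here does respond to the group at this place. The change does not remove activity outright, since compound 4 still gives a number, 20000 nM, but more of it is needed for the same effect. The step swaps several features at once, bringing in a methylene link and a nitro group with 2 hydrogen-bond acceptors while the chlorine and the methyl group leave, and no measurement here explains the rise in the number.

On these data alone, this single step cannot show which of those features matters, so it remains open whether the methylene link, the nitro group or the loss of the chlorine and methyl groups accounts for the shift. A plain benzyl group or a 2-nitrophenyl group at this place would separate the methylene link from the nitro group, and an amine on the benzyl ring would test a different kind of substituent.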